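Aryl replacement on the shared core: compound 2 to compound 3

The compounds below may be only part of what the source reports. "The series", "measured", "known", "first", "only" and "open" are said of these compounds alone.

Measured so far:
Compound 1 `c1ccc2c(-c3cn4ccnc4c(-c4ccc5ncn(C6CCCCC6)c5c4)n3)cccc2c1` gives 41.3% in a functional assay on T47D cells (Homo sapiens) for inhibition, read by sulforhodamine B assay, with a stated time of 48 h, tested at 10 uM; a lower number here means less inhibition, a higher number more inhibition at the concentration tested (going by the name of the read-out).
Compound 2 `Fc1ccccc1-c1cn2ccnc2c(-c2ccc3ncn(C4CCCCC4)c3c2)n1` gives 77.2% in this assay.

For the measured compounds named here, compound 2 stands highest of the two numbers in hand; its only neighbour is compound 1, and the step of a number 35.9 percentage points higher from compound 1 to compound 2 (beyond the scatter) is large and beyond the scatter. The next compound, compound 3 `c1csc(-c2cn3ccnc3c(-c3ccc4ncn(C5CCCCC5)c4c3)n2)c1`, differs from compound 2 in one place: thiophen-2-yl in place of 2-fluorophenyl on an aromatic carbon.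

Going by the values given here, only the step from compound 1 to compound 2 bears on this change, and it bears only loosely: it swapped one six-membered carbon ring for another, whereas here a five-membered ring with one sulfur enters in place of the 2-fluorophenyl. Among the compounds with values here, no measured pair shows a thiophen-2-yl on the shared core, so the direction of the step is not fixed by the data. Given that compound 2 already sits high in this assay, a moderate fall is expected rather than a further rise, with a wide band of uncertainty, and the expected step is a number 12.2 percentage points lower from compound 2 to compound 3 (beyond the scatter). For compound 3 the estimated value in this assay is 65%, within 40% to 85%.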

Compound 3, a percentage reported as inhibition, at one concentration (the size of the read-out at that concentration, not a potency): 70.3%
Beside the measured number, compound 3's estimate is 5.3 percentage points below it, and the stated range covers the measured number.
By their numbers in this assay, from the lowest: compound 1; then compounds 3 and 2 (each within the scatter of the next).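

In this assay, thiophen-2-yl in place of 2-fluorophenyl on this aromatic carbon gives a number 6.9 percentage points lower from compound 2 to compound 3 (within the scatter), so a five-membered aromatic ring with one sulfur and a six-membered aromatic ring of carbon only cannot be told apart at this position. Set against the naphthalen-1-yl of compound 1, the same thiophen-2-yl gives a number 29 percentage points higher from compound 1 to compound 3 (beyond the scatter), so two different groups of one ring each now stand clear of the naphthalen-1-yl, and none of the three compounds goes against this, though the pattern rests on these three alone. No measurement in hand accounts for either step.

On these data alone, it remains open whether the fluorine of the 2-fluorophenyl contributes anything, which a plain phenyl at this position would test, and whether the place of the sulfur matters, which thiophen-3-yl would test. As far as these compounds go, it also remains open whether this carbon needs an aromatic ring at all, a question that an amine or a carboxylic acid at the same place would address.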